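Amide substituent change at the limit of the assay

A few compounds are considered here, and "the series" means these few. Any claim that something is new, unique, unknown or untested is made for them only; others in the source may bear on it.

In a functional assay on K562 cells (Homo sapiens) for cytotoxicity, read by MTT assay, with a stated time of 48 h (a higher number here means a weaker inhibitor, a lower number a stronger inhibitor), compound 1 (`CCOC(=O)[C@@]1(C(=O)Nc2ccccc2)C[C@@H]1c1cc(OC)c(OC)c(OC)c1`) gives > 100000 nM as a limit and not a number. Its mirror image, compound 3 (`CCOC(=O)[C@]1(C(=O)Nc2ccccc2)C[C@H]1c1cc(OC)c(OC)c(OC)c1`), gives > 100000 nM as a limit too. Compound 2 (`COc1cc([C@@H]2C[C@]2(CO)C(=O)NCc2ccc(C)cc2)cc(OC)c1OC`) gives > 100000 nM which is also a limit. Compound 3 thus stands with the others at the limit of > 100000 nM in this assay, at which 3 of the 3 values shown sit, and offers no number to step from.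

Compound 4 (`CCOC(=O)[C@]1(C(=O)NCc2ccc(C)cc2)C[C@H]1c1cc(OC)c(OC)c(OC)c1`) follows with 4-methylbenzyl in place of phenyl on an amide-type nitrogen as its change, 4-methylbenzyl in place of phenyl on an amide-type nitrogen. Among the compounds with values here, the only measured step is a step that the two limits leave unreadable from compound 1 to compound 3 and it concerns only the fact that compounds 1 and 3 differ only in the configuration as drawn so no measured step gives a size for this change. Compound 2 also carries 4-methylbenzyl and sits at the limit > 100000 nM so no gain is foreseen. The expected outcome is a number no higher from compound 3 to compound 4 (the limit leaves the size open) and no step beyond the scatter is expected in this assay from this change. For compound 4 the estimate is 100000 nM with an expected range of 30000 nM to 300000 nM in this series.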

Compound 4, half-maximal inhibitory concentration: > 100000 nM
Compound 4 ended at the assay's limit; the forecaster's own chance of this, stated with the estimate: 70%; the middle value sits exactly at the limit.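

In this assay compound 4 gives > 100000 nM, a limit and not a number. The steps to compound 4 from compound 3 and from compound 2 therefore cannot be read: the limit of > 100000 nM in this assay, at which 4 of the 4 values shown sit.

The compounds shown leave open whether any amide substituent on the shared core gives a measurable number in this assay.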